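Sulfonamide series: ester to carboxamide on the pyridine

The compounds below may be only part of what the source reports. "The series", "measured", "known", "first", "only" and "open" are said of these compounds alone.

Measured so far:
- compound 1, `COc1cc(Cl)ccc1S(=O)(=O)Nc1cccnc1` — 4170 nM
- compound 2, `COc1ccc(C(N)=O)cc1S(=O)(=O)Nc1cccnc1` — 1490 nM
- compound 3, `COC(=O)c1cncc(NS(=O)(=O)c2cc(Cl)ccc2OC)c1` — 65 nM

All three values come from an assay on isolated protein for inhibition of alkaline phosphatase, tissue-nonspecific isozyme (Homo sapiens); a higher number here means a weaker inhibitor, a lower number a stronger inhibitor. Compound 3 holds the lowest number of the three; the nearest is compound 2, and the gap between them is beyond the usual scatter, as is the larger gap to compound 1. Within the data shown here, compound 1 and compound 2 differ from each other in more than one place, and no single-change step between measured compounds is available, so the effect of any one change on the core can only be judged from the measured values themselves.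

The next compound, compound 4, `COc1ccc(Cl)cc1S(=O)(=O)Nc1cncc(C(N)=O)c1`, departs from compound 3 in one place:

amino in place of methoxy on a carbonyl carbon

Among the measured compounds shown here, no measured pair shows this exact change. The methoxycarbonyl on the pyridine of compound 3 goes with the lowest value seen, and compound 2 carries a carbamoyl, though on a different ring and with other differences, so the carbamoyl has appeared only with a higher number. The step from compound 3 to compound 4 in this assay is expected to be a modest rise in the number, possibly within the scatter: a 2.3-fold higher number from compound 3 to compound 4 (0.36 log units; beyond the scatter). For compound 4 the estimate is 150 nM, with a range from 40 nM to 600 nM.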

Compound 4, half-maximal inhibitory concentration: 16 nM
For compound 4 the middle estimate is 9.4-fold (0.97 log units) above the measured one; measured number outside the range, below it.
By their numbers in this assay, from the lowest: compound 4; then compound 3; then compound 2; then compound 1.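

In this assay, methoxycarbonyl to carbamoyl on the pyridine gives a 4.1-fold lower number from compound 3 to compound 4 (0.61 log units; beyond the scatter) and places compound 4 at the low end of the series. Among these compounds, this is the first step between measured compounds that differ in one place, so the carbamoyl can now be read on its own, apart from the other differences that accompanied it in compound 2. At this position the methoxy is not required for a low number, and amino on the same carbonyl carbon, with a hydrogen-bond donor where methoxy has none, goes with a lower number still, although nothing available gives a reason for this step.

The compounds shown leave open whether the gain depends on both hydrogens of the amino group, which a methylamino or dimethylamino on the same carbonyl carbon would test, and whether a carbonyl is needed at all, which a carboxylic acid or a nitrile in place of the carbamoyl would begin to address. On these data alone, this change also rests on a single pair, so whether it holds with other groups on the sulfonyl-bearing ring remains unknown.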